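Swapping the Thiazole for a Furan on Compound 1

The source may report more compounds than this note shows. Statements on the series, on what has been measured and on what is new or still open speak of the compounds shown alone.

Among the compounds with values here, compound 1 `O=C(/C=C/c1nccs1)c1cc(O)c(O)c([N+](=O)[O-])c1` gives the higher of the two numbers measured so far: in an assay for inhibition of Catechol O-methyltransferase (Rattus norvegicus), read by fluorescence and spectrophotometry (on this read-out higher numbers stand for weaker inhibition and lower numbers for stronger inhibition), compound 1 gives 240 nM. Compound 2 `CC(=O)N1N=C(c2cc(O)c(O)c([N+](=O)[O-])c2)CC1c1nccs1` gives 160 nM in this assay, and the two values lie within the scatter of each other, so no order between them can be read. Compound 3 `O=C(/C=C/c1ccco1)c1cc(O)c(O)c([N+](=O)[O-])c1` differs from compound 1 by furan-2-yl in place of 1,3-thiazol-2-yl on a double-bonded chain carbon bound to a double-bonded chain carbon. Within the data shown here, no measured pair shows such a change, so the step of a 1.1-fold lower number from compound 1 to compound 3 (0.04 log units; within the scatter) is expected to stay within the scatter, in no particular direction. Compound 3 is therefore estimated at 220 nM, within a range from 80 nM to 600 nM.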

Compound 3, half-maximal inhibitory concentration: 230 nM
Beside the measured number, compound 3's estimate is 1.0-fold (0.02 log units) below it; the range from low to high includes it.
By their numbers in this assay, from the lowest: compounds 2, 3 and 1 (each within the scatter of the next).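

With furan-2-yl in place of 1,3-thiazol-2-yl, this assay does not tell the two compounds apart (a 1.0-fold lower number from compound 1 to compound 3 (0.02 log units; within the scatter)). This position on a double-bonded chain carbon bound to a double-bonded chain carbon therefore carries either of these five-membered aromatic rings with no readable difference, although the ring nitrogen and sulfur give way to a ring oxygen. No available evidence bears on this result. The compounds shown leave open whether an amine, a carboxylic acid or a phenyl ring at this position would give a number beyond the scatter.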